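This account rests on a few compounds, and the source may have more. Where it says the series, first, only, none or still open, it means among the compounds named here.

Of the compounds shown here, three have been tested in a functional assay on the whole organism (strain Wistar) for inhibition, with Rattus norvegicus as the target, read by paw edema, with stated times of 30 min and 4 h, at a dose of 50 mg/kg by the oral route; on this read-out higher numbers stand for more inhibition at the one dose given (going by the name of the read-out) and lower numbers for less inhibition. Compound 1, `Nc1cc(-c2ccc(Cl)cc2)nc2cc(-c3ccccc3)nn12`, gives 51.2% in this assay. Compound 2, `Cc1ccc(-c2cc(N)n3nc(-c4ccccc4)cc3n2)cc1`, differs from compound 1 by methyl in place of chloro on an aromatic carbon; in this assay compound 2 gives 54.8%; the step of a number 3.6 percentage points higher from compound 1 to compound 2 (within the scatter). Compound 3, `Nc1cc(-c2ccc(Cl)cc2)nc2cc(-c3ccc(Br)cc3)nn12`, differs from compound 1 in bromo in place of hydrogen on an aromatic carbon; in this assay compound 3 gives 65.5%; the step of a number 14.3 percentage points higher from compound 1 to compound 3 (beyond the scatter).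

Compound 4, `Cc1ccc(-c2cc(N)n3nc(-c4ccc(Br)cc4)cc3n2)cc1`, has not yet been measured in this assay. It differs from compound 3 by methyl in place of chloro on an aromatic carbon. For the measured compounds named here, this is the same change as the one from compound 1 to compound 2, made here on the core of compound 3 rather than that of compound 1; the difference between the two cores is bromo in place of hydrogen on an aromatic carbon. Going by the values given here, the change occurs twice among the four compounds, and the one measured instance of it gave a step that was within the scatter.

On that basis the step is expected to be small again: the estimated step of a number 3.5 percentage points higher from compound 3 to compound 4 (within the scatter) rests on the earlier step of a number 3.6 percentage points higher from compound 1 to compound 2 (within the scatter), which carried compound 2 only slightly away from compound 1. Since compound 3 starts from 65.5%, compound 4 is expected to give about 69% in this assay, with a plausible range from 58% to 79%.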

Compound 4, a percentage reported as inhibition, in the whole organism at one dose (the size of the read-out at that dose, not a potency): 64.3%
The estimate for compound 4 lay 4.7 percentage points above the measured number, and the stated range covers the measured number.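

In this assay, for the compounds shown here, methyl in place of chloro on the core of compound 3 gave a step of a number 1.2 percentage points lower from compound 3 to compound 4 (within the scatter), and this agrees with the same change on the core of compound 1: the same change on two cores in this assay, a number 3.6 percentage points higher (within the scatter) from compound 1 to compound 2 and a number 1.2 percentage points lower (within the scatter) from compound 3 to compound 4, 4.8 percentage points apart, within the scatter of two such steps Bromo in place of hydrogen, read on the methyl-bearing pair, gave a step of a number 9.5 percentage points higher from compound 2 to compound 4 (within the scatter), and although only the earlier instance of this change lies beyond the scatter, the two instances do not differ from each other: the same change on two cores in this assay, a number 14.3 percentage points higher (beyond the scatter) from compound 1 to compound 3 and a number 9.5 percentage points higher (within the scatter) from compound 2 to compound 4, 4.8 percentage points apart, within the scatter of two such steps Within these four compounds, then, each change carried over from one core to the other with no detectable dependence on the core, but this rests on only two instances of each change at a single dose, so it shows neither that the agreement extends to other cores nor that smaller differences between the cores are absent.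

The compounds shown leave open whether other groups in the place of chloro, such as methoxy, fluoro or a carboxylic acid, would behave as methyl does on both cores. They also leave open what happens when the amine on the shared core gives way to an amide or a longer chain, and whether the bromo step holds there.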